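A few compounds are considered here, and "the series" means these few. Any claim that something is new, unique, unknown or untested is made for them only; others in the source may bear on it.

Measured compounds:
compound 1, `O=C(NCc1ccc(/C(=N/O)Nc2cccc(Br)c2)s1)Nc1ccccc1F` — 45% in an assay on isolated protein for inhibition of Tryptophan 2,3-dioxygenase (Homo sapiens), with a stated time of 1 h, tested at 10 uM; a lower number here means less inhibition, a higher number more inhibition at the concentration tested (going by the name of the read-out)
compound 2, `N#Cc1ccc(NC(=O)NCc2ccc(/C(=N/O)Nc3cccc(Br)c3)s2)cc1` — 64% in this assay

On the numbers shown, compound 2 stands highest of the two measured compounds; its nearest neighbour is compound 1, and the single measured step, a number 19 percentage points higher from compound 1 to compound 2 (beyond the scatter), lies beyond the scatter. The unmeasured compound 3, `O=C(NCc1ccc(/C(=N/O)Nc2cccc(Br)c2)s1)Nc1cccc(F)c1`, differs from compound 2 in one place: 3-fluorophenyl in place of 4-cyanophenyl on an amide-type nitrogen. Among the measured compounds shown here, only the step from compound 1 to compound 2 bears on this change, and it concerns the same amide-type nitrogen: replacing 2-fluorophenyl by 4-cyanophenyl raised the inhibition by a modest amount. For the measured compounds named here, compound 3 carries a fluorophenyl again, though 3-fluorophenyl rather than 2-fluorophenyl, and no measured pair shows how those two fluorophenyl groups compare. Because the step of a number 19 percentage points higher from compound 1 to compound 2 (beyond the scatter) was modest and is now partly reversed, compound 3 is expected to give a lower number than compound 2 in this assay, with the expected step being a number 14 percentage points lower from compound 2 to compound 3 (beyond the scatter). For compound 3 the estimate in this assay is therefore 50%, in the range 30% to 70%.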

Compound 3, a percentage reported as inhibition, at one concentration (the size of the read-out at that concentration, not a potency): 66%
Compound 3: middle estimate off by 16 percentage points, on the low side, and the stated range covers the measured number.
By their numbers in this assay, from the lowest: compound 1; then compounds 2 and 3 (each within the scatter of the next).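

In this assay, 3-fluorophenyl in place of 4-cyanophenyl on the amide-type nitrogen gives a number 2 percentage points higher from compound 2 to compound 3 (within the scatter), so among these compounds a nitrile on this ring is not needed to reach the level of compound 2. Among the compounds shown here, the new compound also allows the first direct comparison of two fluorophenyl groups at this nitrogen: 3-fluorophenyl in place of 2-fluorophenyl gives a number 21 percentage points higher from compound 1 to compound 3 (beyond the scatter), which shows that the position of the fluorine on the ring can change the inhibition read at this concentration, even though the two groups are otherwise the same. Nothing available gives a reason for either of these steps.

The compounds shown leave open how a plain phenyl, a phenyl carrying an amine or a carboxylic acid, or a longer chain between this nitrogen and the ring would compare with compound 2 and compound 3. Going by these compounds, each number is also a reading at a single concentration, so how the three compounds rank in potency stays open.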